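Sulfonyl chalcone analogues: growth inhibition on DU-145 cells

This account rests on a few compounds, and the source may have more. Where it says the series, first, only, none or still open, it means among the compounds named here.

Measured compounds:
compound 1, `O=C(/C(=C\c1ccc(I)cc1)S(=O)(=O)c1ccc(Br)cc1)c1ccc(Br)cc1`, 1000 nM
compound 2, `CSc1ccc(/C=C(\C(=O)c2ccc(Cl)cc2)S(=O)(=O)Cc2ccc(Cl)cc2)cc1`, 10000 nM
compound 3, `COc1ccccc1/C=C(/SCc1ccc(F)cc1)C(=O)c1ccc(Cl)cc1`, 10000 nM

In a functional assay on DU-145 cells (Homo sapiens) for inhibition, read by trypan blue exclusion, with a stated time of 96 h (on this read-out lower numbers stand for stronger inhibition of growth and higher numbers for weaker inhibition of growth), compound 1 gives the lowest of the three numbers; compound 2 and compound 3 both stand higher, and each of those gaps is beyond the scatter. For the measured compounds named here, no single-point step between measured compounds is available, so compound 4, `O=C(/C(=C\c1ccc(F)c([N+](=O)[O-])c1)S(=O)(=O)c1ccc(Br)cc1)c1ccc(Br)cc1`, is judged against compound 1 alone. The change is 4-fluoro-3-nitrophenyl in place of 4-iodophenyl on a double-bonded chain carbon bound to a double-bonded chain carbon. With nothing in the measured set to calibrate a swap of this kind, the expected step of a 2.0-fold higher number from compound 1 to compound 4 (0.30 log units; within the scatter) is small and toward a somewhat higher number, though a result within the scatter would not surprise. Compound 4 is therefore estimated at 2000 nM, within 500 nM to 8000 nM.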

Compound 4, concentration for 50% growth inhibition: 25000 nM
The estimate for compound 4 lay 13-fold (1.10 log units) below the measured number; the measured number lies above the stated range.
By their numbers in this assay, from the lowest: compound 1; then compounds 2 and 3 (each within the scatter of the next); then compound 4.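

At the double-bonded chain carbon bound to a double-bonded chain carbon, the aryl group is not interchangeable in this assay: 4-fluoro-3-nitrophenyl in place of 4-iodophenyl gives a 25-fold higher number from compound 1 to compound 4 (1.40 log units; beyond the scatter) with the rest of the core unchanged. For the compounds shown here, this is the first single-place comparison, and it marks this position as sensitive to the ring's substituents. Nothing available explains the step.

Iodine leaves while fluorine and the nitro group enter together, so the share of each in the loss stays open. Going by these compounds, how a phenyl ring carrying only fluorine, only a nitro group or an amine would behave here also remains unknown.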